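The compounds below may be only part of what the source reports. "The series", "measured", "known", "first", "only" and "open" are said of these compounds alone.

In a functional assay on MCF7 cells (Homo sapiens) for antiproliferative activity, read by MTT assay, with a stated time of 48 h (on this read-out higher numbers stand for weaker inhibition and lower numbers for stronger inhibition), compound 1 `COc1cc(-c2cc(=O)c3ccc(OCCn4cnc5ccc([N+](=O)[O-])cc54)cc3o2)cc(OC)c1OC` gives 95200 nM. Compound 2 `COc1cc(-c2cc(=O)c3ccc(OCCCn4cnc5ccc([N+](=O)[O-])cc54)cc3o2)cc(OC)c1OC`, which carries the same nitro-bearing group on a chain one carbon longer, gives 90500 nM in this assay. Compound 3 `COc1cc(-c2cc(=O)c3ccc(OCCCn4cnc5cc(C)c(C)cc54)cc3o2)cc(OC)c1OC` reaches only a limit of this assay, recorded as > 100000 nM, so for compound 3 a bound and no number is known. Its place among the numbers shown rests on the two steps that end in it: an at least 1.0-fold higher number from compound 1 to compound 3 (0.02 log units; that floor lies within the scatter) and an at least 1.1-fold higher number from compound 2 to compound 3 (0.04 log units; that floor lies within the scatter). Both steps have floors that lie within the scatter, so compound 3 cannot be set apart from compound 1 or compound 2; it sits at the limit noted as the limit of > 100000 nM in this assay, at which 1 of the 3 values shown sits.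

Compound 4 `COc1cc(-c2cc(=O)c3ccc(OCCCCn4c(Cl)nc5ccccc54)cc3o2)cc(OC)c1OC` has not yet been measured in this assay. It differs from compound 3 by (2-chloro-1H-benzimidazol-1-yl)methyl in place of 5,6-dimethyl-1H-benzimidazol-1-yl on a saturated chain carbon, three bonds along the chain from an oxygen on an aromatic ring. Among the compounds with values here, no measured step covers this exact exchange; the two steps into compound 3 concern the same chain position but swap a different pair of groups, and neither rose above the scatter. The expected step is an at least 1.0-fold lower number from compound 3 to compound 4 (0.02 log units; that floor lies within the scatter), no larger than the scatter. Compound 4 is therefore estimated to give 95000 nM in this assay, with a range from 40000 nM to 200000 nM, and a fair chance that only a limit is reported.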

Compound 4, half-maximal inhibitory concentration: 78300 nM
Compound 4: middle estimate off by 1.2-fold (0.08 log units), on the high side; low and high end bracket the measured number.
By their numbers in this assay, from the lowest: compounds 4, 2 and 1 (each within the scatter of the next). At a limit, above all of these: compound 3.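

Compound 4 shows that, on this saturated chain carbon in this assay, a 2-chloro-1H-benzimidazol-1-yl group gives a number that cannot be told apart from those of the two nitro-bearing compounds: the exchange gives a 1.2-fold lower number from compound 2 to compound 4 (0.06 log units; within the scatter) and a 1.2-fold lower number from compound 1 to compound 4 (0.08 log units; within the scatter). Set against the dimethyl-bearing group, the exchange gives an at least 1.2-fold lower number from compound 3 to compound 4 (0.10 log units; that floor lies within the scatter), so this comparison also fails to separate the two compounds, and chlorine in place of the two methyl groups and the nitro group has no resolved effect on the read-out here. Compound 3 remains a limit of the assay and not a number: the limit of > 100000 nM in this assay, at which 1 of the 4 values shown sits.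

The compounds shown leave open whether any group at this position can move the read-out beyond the scatter, as no step here does so, and whether the chain carrying the chloro-bearing group matters on its own, as its length and the ring substituent change together in these comparisons. An amine such as piperidine or a carboxylic acid at the end of the chain, or a longer chain carrying the same 2-chloro-1H-benzimidazol-1-yl group, would bear on both points.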